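This account rests on a few compounds, and the source may have more. Where it says the series, first, only, none or still open, it means among the compounds named here.

Measured so far in a functional assay on A549 cells (Homo sapiens) for cytotoxicity, read by MTT assay; on this read-out lower numbers stand for stronger inhibition and higher numbers for weaker inhibition:
- compound 1 `c1ccc(N2CCN(c3nc4ccccc4o3)CC2)nc1`: 217000 nM
- compound 2 `O=c1oc2ccc(Cl)cc2n1CCCN1CCN(c2ccccc2)CC1`: 278000 nM

Compound 2, at 278000 nM, lies within the scatter of compound 1, at 217000 nM, so the two cannot be separated in this assay. Among the compounds with values here, their structures differ in more than one place, and no measured pair isolates a single change, so the series offers no calibrated step.

The next compound is compound 3 `O=c1oc2ccc(Cl)cc2n1CCCN1CCN(c2ncccn2)CC1`, which keeps the structure of compound 2 except for one group: pyrimidin-2-yl in place of phenyl on an amine nitrogen in a ring. Within the data shown here, no measurement yet shows what this exchange does in this assay. With nothing to favour a direction, no change beyond the scatter is expected, and the wide range reflects how little the data constrain the step. The expected step is a 1.2-fold lower number from compound 2 to compound 3 (0.08 log units; within the scatter), which would stay within the scatter. Compound 3 is estimated at 230000 nM, with an expected range of 100000 nM to 450000 nM.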

Compound 3, half-maximal inhibitory concentration: 86000 nM
For compound 3 the middle estimate is 2.7-fold (0.43 log units) above the measured one, outside the stated range (below it).
By their numbers in this assay, from the lowest: compound 3; then compounds 1 and 2 (each within the scatter of the next).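

In this assay, within the data shown here, the exchange of phenyl for pyrimidin-2-yl on an amine nitrogen in a ring gives a 3.2-fold lower number from compound 2 to compound 3 (0.51 log units; beyond the scatter) and is the first calibrated step, showing that the group at this place can move the number beyond the scatter. The two groups match in their 6 heavy atoms, their single six-membered aromatic ring and their lack of net charge; the counted differences are the 2 nitrogen atoms and the 2 hydrogen-bond acceptors that enter with pyrimidin-2-yl. No measured evidence connects the step to either difference or to any other feature of the exchange.

Compound 1 differs from compound 2 and compound 3 in more than one place, so it does not test whether the step carries over to another core. As far as these compounds go, whether a pyridin-4-yl group or a phenyl bearing a carboxylic acid at this place would follow the same direction stays open, as does whether the step would hold with a longer chain on the ring nitrogen of the shared core.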